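The source may hold more compounds than are shown below. What is called first, only, known or untested is meant among the compounds shown, and "the series" means these compounds.

Compound 3 `CCN(CC)C/C=C/C(=O)Nc1cc2c(N3CCCc4ccccc43)ncnc2cc1OC` is the weakest of the three measured compounds: in a functional assay on MCF7 cells (Homo sapiens) for antiproliferative activity, read by MTT assay, with a stated time of 72 h (a lower number here means a stronger inhibitor, a higher number a weaker inhibitor), compound 3 gives 5310 nM. Compound 1 `CCC/C=C/C(=O)Nc1cc2c(N3CCCc4ccccc43)ncnc2cc1OC` gives 1210 nM, and compound 2 `COc1cc2ncnc(N3CCc4ccccc43)c2cc1NC(=O)/C=C/CN1CCCCC1` gives 1680 nM. Within the data shown here, the only measured step, a 4.4-fold higher number from compound 1 to compound 3 (0.64 log units; beyond the scatter), concerns a different exchange at the same place. Compound 4 `COc1cc2ncnc(N3CCCc4ccccc43)c2cc1NC(=O)/C=C/CN1CCCCC1` differs from compound 3 by piperidin-1-yl in place of diethylamino on a saturated chain carbon bound to a double-bonded chain carbon. Among the measured compounds shown here, compound 2 carries the same piperidin-1-yl group on a different core, and its number sits lower than that of compound 3, but no measured step separates the two amines directly. Compound 4 is therefore expected to shift only modestly toward a lower number, by a 1.8-fold lower number from compound 3 to compound 4 (0.25 log units; within the scatter). The estimate for compound 4 is 3000 nM, with a range from 1200 nM to 8000 nM.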

Compound 4, half-maximal inhibitory concentration: 3930 nM
The estimate for compound 4 lay 1.3-fold (0.12 log units) below the measured number, and the stated range covers the measured number.
By their numbers in this assay, from the lowest: compounds 1 and 2 (each within the scatter of the next); then compounds 4 and 3 (each within the scatter of the next).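

Exchanging diethylamino for piperidin-1-yl on the saturated chain carbon gives a 1.4-fold lower number from compound 3 to compound 4 (0.13 log units; within the scatter) and so does not separate the two amines. Ethyl at this place still gives the lower number against piperidin-1-yl, with a 3.2-fold higher number from compound 1 to compound 4 (0.51 log units; beyond the scatter) on the shared core. With the piperidin-1-yl chain held fixed, 1,2,3,4-tetrahydroquinolin-1-yl in place of 2,3-dihydro-1H-indol-1-yl on the aromatic carbon gives a 2.3-fold higher number from compound 2 to compound 4 (0.37 log units; beyond the scatter) and thus moves the number beyond the scatter.

From the compounds shown here alone, whether a morpholin-4-yl or dimethylamino group on the chain would match these two amines stays open. No evidence here explains any of these shifts.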